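Series notes: a halogen enters on the hydroxyphenyl ring

The compounds below may be only part of what the source reports. "The series", "measured", "known", "first", "only" and "open" are said of these compounds alone.

Compound 1 `Cc1c(C(=O)N/N=C\c2ccccc2O)oc2cccc(O)c12` carries the highest number of the three measured in a functional assay on PC-3 cells (Homo sapiens) for inhibition (a lower number here means a stronger inhibitor, a higher number a weaker inhibitor), giving 8350 nM. Compound 2 `Cc1ccc(O)c(/C=N\NC(=O)c2oc3cccc(O)c3c2C)c1` gives 7350 nM, and compound 3 `Cc1c(C(=O)N/N=C\c2cc(Cl)ccc2O)oc2cccc(O)c12` gives 3120 nM. The step of a 1.1-fold lower number from compound 1 to compound 2 (0.06 log units; within the scatter) stays within the scatter, whereas a 2.7-fold lower number from compound 1 to compound 3 (0.43 log units; beyond the scatter) and a 2.4-fold lower number from compound 2 to compound 3 (0.37 log units; beyond the scatter) are modest but beyond it. Compound 4 `Cc1c(C(=O)N/N=C\c2cccc(Br)c2O)oc2cccc(O)c12` differs from compound 1 by bromo in place of hydrogen on an aromatic carbon. Going by the values given here, the only measured precedent for a halogen entering this series is a 2.7-fold lower number from compound 1 to compound 3 (0.43 log units; beyond the scatter), so a modest move toward a lower number in this assay is expected for compound 4, a 2.4-fold lower number from compound 1 to compound 4 (0.38 log units; beyond the scatter). Compound 4 is estimated at 3500 nM, with a range from 1500 nM to 8000 nM.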

Compound 4, half-maximal inhibitory concentration: 16600 nM
The estimate for compound 4 lay 4.7-fold (0.68 log units) below the measured number; the whole stated range lies below it.
By their numbers in this assay, from the lowest: compound 3; then compounds 2, 1 and 4 (each within the scatter of the next, the first and the last beyond it).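

In this assay bromo ortho to a hydroxy group gives a 2.0-fold higher number from compound 1 to compound 4 (0.30 log units; within the scatter) and so shows that a halogen on this ring does not by itself bring a lower number. The steps of a 5.3-fold higher number from compound 3 to compound 4 (0.73 log units; beyond the scatter) and a 2.3-fold higher number from compound 2 to compound 4 (0.35 log units; beyond the scatter) both lie beyond the scatter, but each changes both the group and its place on the ring, so neither isolates one factor. No measured evidence on the cause of this result is available.

Still open, as far as these compounds go, is whether the halogen or its place on the ring sets the difference between these compounds. Also open, from the compounds shown here alone, is how an amine or a methoxy group would read ortho to the hydroxy group.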